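Cyano and tetrazole steps on a thiazolylidene hydrazide core

The source may hold more compounds than are shown below. What is called first, only, known or untested is meant among the compounds shown, and "the series" means these compounds.

Three compounds are measured in a functional assay on C6 cells (Rattus norvegicus) for cytotoxicity, read by MTT assay, with a stated time of 24 h, tested at 25 ug/mL; on this read-out lower numbers stand for a stronger effect and higher numbers for a weaker effect at the one concentration tested. Compound 2 `Cn1cnnc1SCC(=O)N/N=c1/scc(-c2ccccc2)n1-c1ccccc1` gives 77.3%. Compound 1 `Cn1cnnc1SCC(=O)N/N=c1/scc(-c2ccc(C#N)cc2)n1-c1ccccc1` carries cyano in place of hydrogen on an aromatic carbon and gives 58.8%, a step of a number 18.5 percentage points lower from compound 2 to compound 1 (beyond the scatter). Compound 3 `O=C(CSc1nnnn1-c1ccccc1)N/N=c1/scc(-c2ccccc2)n1-c1ccccc1` carries 1-phenyl-1H-tetrazol-5-yl in place of 4-methyl-4H-1,2,4-triazol-3-yl on a sulfur and gives 42.5%, a step of a number 34.8 percentage points lower from compound 2 to compound 3 (beyond the scatter); among the three, compound 3 has the lowest number, with every step to the others beyond the scatter.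

Compound 4 `N#Cc1ccc(-c2cs/c(=N/NC(=O)CSc3nnnn3-c3ccccc3)n2-c2ccccc2)cc1` is not yet measured. Against compound 3 it carries cyano in place of hydrogen on an aromatic carbon; the place is described in the same words as for compound 1 against compound 2, so the change is the same one, seen here for the second time, on the core of compound 3 instead of the core of compound 2.

The step in this assay from compound 3 to compound 4 is expected at a number 15.5 percentage points lower from compound 3 to compound 4 (beyond the scatter), set beside the earlier one, because a number 18.5 percentage points lower from compound 2 to compound 1 (beyond the scatter) lay beyond the scatter in the same direction, with some allowance for the lower starting point of compound 3. Compound 4 is therefore estimated at 27%, between 12% and 45%.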

Compound 4, a percentage reported as activity, at one concentration (the size of the read-out at that concentration, not a potency): 64.2%
Compound 4: the middle estimate sits 37.2 percentage points below what was measured; measured number above the stated range.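

On the core of compound 3, the cyano change gives a number 21.7 percentage points higher from compound 3 to compound 4 (beyond the scatter), so in this assay its direction does not carry over from the core of compound 2: the same change on two cores in this assay, a number 18.5 percentage points lower (beyond the scatter) from compound 2 to compound 1 and a number 21.7 percentage points higher (beyond the scatter) from compound 3 to compound 4, 40.2 percentage points apart, beyond the scatter of two such steps

The swap to 1-phenyl-1H-tetrazol-5-yl, read on the cyano-bearing core, gives a number 5.4 percentage points higher from compound 1 to compound 4 (within the scatter), so the step seen without cyano does not carry over either: the same change on two cores in this assay, a number 34.8 percentage points lower (beyond the scatter) from compound 2 to compound 3 and a number 5.4 percentage points higher (within the scatter) from compound 1 to compound 4, 40.2 percentage points apart, beyond the scatter of two such steps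

Across these four compounds the two changes do not add, but with one pair of cores per change this gives no cause and does not show whether the same reversal would hold for other groups; a read-out at one concentration also gives no potency.

Open, from the compounds shown here alone, is whether an amine or a carboxylic acid in place of cyano, para to the same large group, would follow the step to compound 1 or the step to compound 4. Also open, going by these compounds, is how a third ring on the sulfur, such as 1-methyl-1H-imidazol-2-yl, would behave on these two cores.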